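Moving the Bromine on the Sulfur-Linked Ring

A few compounds are considered here, and "the series" means these few. Any claim that something is new, unique, unknown or untested is made for them only; others in the source may bear on it.

Three compounds have been measured in a functional assay on DU-145 cells (Homo sapiens) for inhibition, read by trypan blue exclusion, with a stated time of 96 h; on this read-out higher numbers stand for weaker inhibition of growth and lower numbers for stronger inhibition of growth:
Compound 1, `CN(C)c1ccc(/C=C(/SCc2ccc(F)cc2)C(=O)c2ccc(Br)cc2)cc1`, gives 50000 nM.
Compound 2, `O=C(/C(=C\c1ccc(O)c([N+](=O)[O-])c1)Sc1ccccc1Br)c1ccc(Br)cc1`, gives 10000 nM.
Compound 3, `O=C(O)c1ccc(C(=O)/C(=C\c2ccc(F)c([N+](=O)[O-])c2)SCc2ccc(C(F)(F)F)cc2)cc1`, gives 1000 nM.

Among these three numbers compound 2 stands second highest. Its nearest neighbour is compound 1, whose number is higher by a margin beyond the usual scatter, and compound 3 lies furthest from it, with a lower number that is also beyond the scatter. No two of the measured compounds differ in only one place, so none of these gaps can be tied to a single structural change.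

Compound 4, `O=C(/C(=C\c1ccc(O)c([N+](=O)[O-])c1)Sc1ccc(Br)cc1)c1ccc(Br)cc1`, has the same atoms as compound 2, joined differently. Among the measured compounds shown here, the one change is 4-bromophenyl in place of 2-bromophenyl on a sulfur. The sulfur whose other neighbour is a double-bonded chain carbon keeps an aromatic ring carrying bromine; the 2-bromophenyl ring is simply exchanged for its 4-bromophenyl counterpart.

For the measured compounds named here, with no measured pair differing in one place, there is no step in this assay to draw on. Such a rearrangement is expected to give a small step, leaning toward a lower number but quite possibly not beyond the scatter. The expected step is a 1.4-fold lower number from compound 2 to compound 4 (0.15 log units; within the scatter). Compound 4 is estimated at 7000 nM, within a range from 2000 nM to 25000 nM.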

Compound 4, concentration for 50% growth inhibition: 1000 nM
Estimate against measurement, compound 4: 7.0-fold (0.85 log units) above; measured number below the stated range.
By their numbers in this assay, from the lowest: compounds 3 and 4 (each within the scatter of the next); then compound 2; then compound 1.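

In this assay, among the compounds shown here, the move of the bromine gives a 10-fold lower number from compound 2 to compound 4 (1.00 log units; beyond the scatter), and this is the first step here that can be tied to a single structural change. The two compounds have the same atoms, and with 4-bromophenyl in place of 2-bromophenyl on the sulfur, the read-out responds to where the bromine stands on this ring and not only to whether a bromine-bearing ring is present. Nothing measured here explains why this rearrangement changes the number.

On these data alone, it remains open whether the same shift would appear with another atom or group on this ring, such as chlorine or methoxy, or whether it belongs to bromine alone. It is also unknown whether the step would hold if the rest of the molecule changed, since this single pair shares the same hydroxy- and nitro-bearing ring and the same 4-bromophenyl ketone, and one pair cannot show how far the effect of the move carries to other members of the series.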